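The compounds below may be only part of what the source reports. "The series", "measured", "known", "first", "only" and "open" are said of these compounds alone.

Measured compounds:
- compound 1 `Cc1cc(C(=O)N2CCCCc3ccccc32)ccc1CNC(=O)Nc1ccccc1`: 130 nM
- compound 2 `CCOC(=O)CNC(=O)NCc1ccc(C(=O)N2CCCCc3ccccc32)cc1C`: 140 nM
- compound 3 `Cc1cc(C(=O)N2CCCCc3ccccc32)ccc1CNC(=O)N1CCC[C@H]1C(=O)O`: 680 nM

All three share a core and differ only in the group attached to the urea carbonyl carbon. In a functional assay on HEK293 cells for agonist activity at Vasopressin V2 receptor (Homo sapiens), read by a luciferase reporter and cAMP accumulation (on this read-out lower numbers stand for an effect already at smaller amounts and higher numbers for an effect only at larger amounts of compound), compound 1 gives the lowest of the three numbers; compound 2 sits within the scatter of it, as a 1.1-fold higher number from compound 1 to compound 2 (0.03 log units; within the scatter) shows, while compound 3 lies further away, with a 5.2-fold higher number from compound 1 to compound 3 (0.72 log units; beyond the scatter) and a 4.9-fold higher number from compound 2 to compound 3 (0.69 log units; beyond the scatter).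

Compound 4 `Cc1cc(C(=O)N2CCCCc3ccccc32)ccc1CNC(=O)N1CCC[C@H]1C(=S)N(C)C` is the next step from compound 1: a group of 10 heavy atoms (7 carbon, 2 nitrogen, 1 sulfur; one five-membered non-aromatic ring with 1 hetero atom) in place of a group of 7 heavy atoms (6 carbon, 1 nitrogen; one six-membered aromatic ring of carbon only), on a carbonyl carbon

Going by the values given here, the closest measured step is the one from compound 1 to compound 3, where the anilino group also gave way to a five-membered non-aromatic ring with one hetero atom, and the number rose by a modest margin. Compound 4 carries a related ring but without the carboxylic acid, and compound 2 shows that a change without the acid can stay within the scatter. A modest rise, smaller than that of compound 3, is therefore expected, though the direction is not certain.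

For compound 4 the expected value in this assay is 300 nM, with a likely range from 100 nM to 900 nM. This estimate corresponds to a step of a 2.3-fold higher number from compound 1 to compound 4 (0.36 log units; beyond the scatter).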

Compound 4, half-maximal effective concentration: 3.2 nM
Estimate against measurement, compound 4: 94-fold (1.97 log units) above; the whole stated range lies above it.
By their numbers in this assay, from the lowest: compound 4; then compounds 1 and 2 (each within the scatter of the next); then compound 3.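

Going by these compounds alone, the group on this carbonyl carbon can shift the number far more than the earlier compounds showed: in this assay there is a 41-fold lower number from compound 1 to compound 4 (1.61 log units; beyond the scatter) and a 44-fold lower number from compound 2 to compound 4 (1.64 log units; beyond the scatter) as well. The five-membered ring is present in both compound 3 and compound 4, and replacing the carboxylic acid on its saturated ring carbon with a dimethylthioamide gives a 210-fold lower number from compound 3 to compound 4 (2.33 log units; beyond the scatter), so the ring alone does not set the number. The data shown offer no explanation for this large change.

On these data alone, what the matching dimethylcarboxamide, with oxygen in place of sulfur, would give remains open, so the contribution of the sulfur cannot be separated from that of the dimethylamino group. Also open, as far as these compounds go, is how a six-membered piperidine ring, or the opposite stereocentre on the five-membered ring, would behave.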